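A methoxy for a methyl at the cytotoxicity limit

This account rests on a few compounds, and the source may have more. Where it says the series, first, only, none or still open, it means among the compounds named here.

Compound 1, `C/C(=N\Nc1nc(-c2ccc(Br)cc2)cs1)c1sc(C)nc1C`: in a toxicity assay on HCT-116 cells (Homo sapiens) for cytotoxicity, read by MTT assay (a higher number here means a weaker inhibitor of growth, a lower number a stronger inhibitor of growth), compound 1 gives > 100 ug/mL, a limit of the assay.
Compound 2, `C/C(=N\Nc1nc(-c2ccc(C)cc2)cs1)c1sc(C)nc1C`: in this assay compound 2 gives > 100 ug/mL, likewise a limit.

Compound 2 therefore stands at the ceiling of this assay, with no number of its own, and the same holds for compound 1, as the limit of > 100 ug/mL in this assay, at which 2 of the 2 values shown sit, records. For the measured compounds named here, the only measured step, a step that the two limits leave unreadable from compound 1 to compound 2, is unreadable in size because the limit of > 100 ug/mL in this assay, at which 2 of the 2 values shown sit, leaves both ends without a number.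

Compound 3, `COc1ccc(-c2csc(N/N=C(\C)c3sc(C)nc3C)n2)cc1`, differs from compound 2 by methoxy in place of methyl on an aromatic carbon. Going by the values given here, no measured step bears directly on this change; the one step that is available says only that exchanging one small group for another in this place left the value at the limit. Compound 3 is thus expected near the same limit, with an estimate of 150 ug/mL and a range from 50 ug/mL to 400 ug/mL, most likely reported again as a limit rather than a number. The step from compound 2 to compound 3 implied by this estimate, a step that the limit leaves unreadable from compound 2 to compound 3, is expected to stay within the scatter.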

Compound 3, concentration for 50% growth inhibition: > 100 ug/mL
Compound 3: only a limit was reported; the forecaster's own chance of this, stated with the estimate: 80%; the middle value is on the limit's open side.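

For the compounds shown here, no step among compound 1, compound 2 and compound 3 can be read, because all three results are limits rather than numbers: the limit of > 100 ug/mL in this assay, at which 3 of the 3 values shown sit.

In this assay the compounds shown leave open whether any group on this aromatic carbon would give a value that can be read as a number.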